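The source may report more compounds than this note shows. Statements on the series, on what has been measured and on what is new or still open speak of the compounds shown alone.

Three compounds have been measured in a functional assay on LNCaP cells (Homo sapiens) for cytotoxicity, read by MTT assay, with a stated time of 72 h; on this read-out higher numbers stand for weaker inhibition and lower numbers for stronger inhibition:

Compound 1 `COc1cc(/C=C/C(=O)/C=C/C2=C(C)CCCC2(C)C)ccc1O` gives 9500 nM.
Compound 2 `COc1ccc(/C=C/C(=O)/C=C/C2=C(C)CCCC2(C)C)cc1OC` gives 9500 nM.
Compound 3 `CC1=C(/C=C/C(=O)/C=C/c2cccc(F)c2)C(C)(C)CCC1` gives 12900 nM.

Compound 1 and compound 2 share one value at the digits shown, and the number for compound 3 lies within the usual scatter of that value, so the three measured compounds cannot be told apart on this read-out. Compound 4 `CC1=C(/C=C/C(=O)/C=C/c2ccc(O)c([N+](=O)[O-])c2)C(C)(C)CCC1` is a new member of the series. Set against compound 1, it carries nitro in place of methoxy on an aromatic carbon. Within the data shown here, only one measured step touches a group on this ring: the step of no change at the digits printed from compound 1 to compound 2 (within the scatter), in which a hydroxy group was capped as methoxy and the number did not move. Among the measured compounds shown here, that step says a small change on the ring with a large group can pass unnoticed here, but it does not cover a nitro group entering in place of a methoxy group, and no measured pair does. With no guide pointing in either direction, the expectation for compound 4 is a number close to that of compound 1, with the step of no change at the digits printed from compound 1 to compound 4 (within the scatter) expected to stay inside the scatter. The estimate for compound 4 in this assay is therefore 9500 nM, expected to fall between 3500 nM and 26000 nM.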

Compound 4, half-maximal inhibitory concentration: 26800 nM
Compound 4: middle estimate off by 2.8-fold (0.45 log units), on the low side; measured number outside the range, above it.
By their numbers in this assay, from the lowest: compounds 1, 2 and 3 (each within the scatter of the next); then compound 4.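

In this assay, nitro in place of methoxy on this aromatic carbon gives a 2.8-fold higher number from compound 1 to compound 4 (0.45 log units; beyond the scatter) and so marks weaker inhibition, a modest step but the first one here to pass beyond the scatter. The earlier step, no change at the digits printed from compound 1 to compound 2 (within the scatter) with a methyl placed on the hydroxy oxygen, had suggested that the ring might tolerate small edits, whereas this result shows that the carbon ortho to a hydroxy group and meta to a large group is not indifferent to what it carries. No measurement available here accounts for the size or direction of this step.

A single swap at this carbon cannot separate the effect of nitro entering from that of methoxy leaving, so the change in the number cannot be assigned to either group alone. On these data alone, it remains open whether a plain hydrogen, an amine or a carboxylic acid on the same carbon would stay level with compound 1 or move the number as nitro does, and whether any group here could move it the other way, towards stronger inhibition.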